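Three Anilines at the Assay Limit, and a Fourth

The source may report more compounds than this note shows. Statements on the series, on what has been measured and on what is new or still open speak of the compounds shown alone.

Compound 1 `CN(c1cccc2c1CN(c1nc(Nc3ccc(Cl)c(C(F)(F)F)c3)ncc1C(F)(F)F)C2)S(C)(=O)=O`: > 50000 nM
Compound 2 `CN(c1cccc2c1CN(c1nc(Nc3cccc(C(F)(F)F)c3)ncc1C(F)(F)F)C2)S(C)(=O)=O`: > 30000 nM
Compound 3 `Cc1cc(C)cc(Nc2ncc(C(F)(F)F)c(N3Cc4cccc(N(C)S(C)(=O)=O)c4C3)n2)c1`: > 30000 nM

In a functional assay on OVCAR-3 cells (Homo sapiens) for antiproliferative activity, read by spectrophotometry, with a stated time of 2 days (a higher number here means a weaker inhibitor of growth, a lower number a stronger inhibitor of growth), compound 1 gives > 50000 nM, which is a limit of the assay and not a number. Compound 2 likewise gives only a limit, > 30000 nM. Compound 3 also gives only a limit, > 30000 nM. Compound 1 therefore stands at a limit, and so do the other two measured compounds. The three steps among them, a step that the two limits leave unreadable from compound 1 to compound 2, a step that the two limits leave unreadable from compound 1 to compound 3 and a step that the two limits leave unreadable from compound 2 to compound 3, cannot be sized, since the two limits the limit of > 30000 nM in this assay, at which 2 of the 3 values shown sit, and the limit of > 50000 nM in this assay, at which 1 of the 3 values shown sits, leave them unreadable.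

Compound 4 `Cc1ccc(Nc2ncc(C(F)(F)F)c(N3Cc4cccc(N(C)S(C)(=O)=O)c4C3)n2)c(C)c1` has not been measured. It differs from compound 1 in one place: 2,4-dimethylphenyl in place of 4-chloro-3-(trifluoromethyl)phenyl on a nitrogen on an aromatic ring. Going by the values given here, the steps that bear on this change are those from compound 1 to compound 3 and from compound 2 to compound 3, in which 3,5-dimethylphenyl took the place of the trifluoromethyl-carrying aryl groups, and neither could be read. Among the compounds with values here, no step among the measured compounds lifts any of them off a limit, so no step beyond the scatter is expected in this assay in either direction. Compound 4 is therefore expected to sit near the limit as well, with an at least 1.2-fold lower number from compound 1 to compound 4 (0.09 log units; that floor lies within the scatter) estimated as essentially no change. Compound 4 is estimated at 40000 nM, between 10000 nM and 100000 nM, and most likely reported only as a limit.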

Compound 4, concentration for 50% growth inhibition: > 30000 nM
Compound 4 gave a limit, no number (the forecaster's own chance of this, stated with the estimate: 80%); the middle value lies beyond the limit too.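

In this assay compound 4 gives > 30000 nM, which is a limit of the assay and not a number. Going by these compounds alone, its steps to compound 1, compound 2 and compound 3 cannot be read, so no new step emerges. The compounds shown leave open whether exchanging the aryl group on this nitrogen changes growth inhibition at all, as none yields a number.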